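The compounds below may be only part of what the source reports. "The series", "measured", "known", "first", "only" and "open" are said of these compounds alone.

Measured so far:
compound 1 `CCCCC(N)c1cc(C(F)(F)F)ccc1N1CCN(C(=O)CCc2ccc(Cl)cc2Cl)CC1` — 190 nM
compound 2 `CCC(C)C(N)c1cc(C(F)(F)F)ccc1N1CCN(C(=O)CCc2ccc(Cl)cc2Cl)CC1` — 160 nM
compound 3 `CCC(C)[C@H](NC(=O)CN)c1cc(C(F)(F)F)ccc1N1CCN(C(=O)CCc2ccc(Cl)cc2Cl)CC1` — 18 nM

The three compounds were tested in an assay on HEK293 cells for displacement of a labelled ligand from Melanocortin receptor 4 (Homo sapiens); on this read-out higher numbers stand for weaker inhibition and lower numbers for stronger inhibition. Compound 3 gives the lowest number of the three: the step of an 8.9-fold lower number from compound 2 to compound 3 (0.95 log units; beyond the scatter) and the step of an 11-fold lower number from compound 1 to compound 3 (1.02 log units; beyond the scatter) both lie beyond the scatter, so compound 3 stands clearly apart from compound 1 and compound 2.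

Compound 4 `CC(C)C[C@H](NC(=O)CN)c1cc(C(F)(F)F)ccc1N1CCN(C(=O)CCc2ccc(Cl)cc2Cl)CC1` has not yet been measured. Relative to compound 3 the change is isobutyl in place of sec-butyl on a saturated chain carbon bound to an amide-type nitrogen and an aromatic carbon. Among the measured compounds shown here, the one measured step that speaks to a reshaping of this saturated chain is a 1.2-fold lower number from compound 1 to compound 2 (0.07 log units; within the scatter), which stayed within the scatter. Compound 3 carries the same chain as compound 2, and the other two steps concern the group on the nitrogen, not the chain, so they offer no further guide.

On that basis compound 4 is expected to lie close to compound 3, with a step of a 1.1-fold higher number from compound 3 to compound 4 (0.05 log units; within the scatter) that stays within the scatter. The estimate for compound 4 is 20 nM, within the range 8 nM to 50 nM.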

Compound 4, inhibition constant: 19 nM
The estimate for compound 4 lay 1.1-fold (0.02 log units) above the measured number, and the stated range covers the measured number.
By their numbers in this assay, from the lowest: compounds 3 and 4 (each within the scatter of the next); then compounds 2 and 1 (each within the scatter of the next).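

In this assay, isobutyl in place of sec-butyl on the saturated chain carbon bound to an amide-type nitrogen and an aromatic carbon gives a 1.1-fold higher number from compound 3 to compound 4 (0.02 log units; within the scatter), so the two chains cannot be told apart once the nitrogen carries the aminomethyl carbonyl group, just as butyl and sec-butyl could not on the free amine. The lower numbers seen with that group are also not tied to the sec-butyl chain of compound 3, since an 8.4-fold lower number from compound 2 to compound 4 (0.93 log units; beyond the scatter) and a 10-fold lower number from compound 1 to compound 4 (1.00 log units; beyond the scatter) both lie beyond the scatter. No measurement is available that would explain these results.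

As far as these compounds go, whether the same holds for a cyclohexyl or a methyl group on this carbon remains open. So does the outcome with a longer amino acyl group on the nitrogen, such as 3-aminopropanoyl.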